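The source may hold more compounds than are shown below. What is called first, only, known or untested is meant among the compounds shown, and "the series" means these compounds.

Compound 1 `COC(=O)c1ccc(NCc2cncn2Cc2ccc(N)cc2)cc1-c1ccccc1` in a toxicity assay on NIH3T3 cells (Mus musculus) for cytotoxicity, read by resazurin assay (a lower number here means that less compound is needed, a higher number that more compound is needed for the effect), gives > 10000 nM, a limit.
Compound 2 `Cc1ccccc1-c1cccc(NCc2cncn2Cc2ccccc2)c1` in this assay gives > 1000 nM, a limit.
Compound 3 `c1ccc(-c2ccc(Cn3cncc3CNc3ccccc3-c3ccccc3)cc2)cc1` in this assay gives > 10000 nM, a limit.

None of the three measured compounds yields a number in this assay. Compound 1 stands at the limit of > 10000 nM in this assay, at which 2 of the 3 values shown sit, shared with compound 3. Compound 2 stands at the limit of > 1000 nM in this assay, at which 1 of the 3 values shown sits.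

Compound 4 `COC(=O)c1ccc(NCc2cncn2Cc2cccc(C(C)(C)C)c2)cc1-c1ccccc1` is the next compound, differing from compound 1 by 3-(tert-butyl)phenyl in place of 4-aminophenyl on a saturated chain carbon bound to an aromatic nitrogen. No step between two measured compounds is available to size this change in this assay, and the shown values, all limits, give no direction. The expected step from compound 1 to compound 4 is therefore a step that the limit leaves unreadable from compound 1 to compound 4, none beyond the scatter. Compound 4 is estimated at 15000 nM, within 5000 nM to 40000 nM, most likely again reported only as a limit.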

Compound 4, half-maximal effective concentration: > 1000 nM
Compound 4 ended at the assay's limit; the forecaster's own chance of this, stated with the estimate: 75%; the middle value lies beyond the limit too.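

Going by these compounds alone, compound 1 and compound 4 are both reported only as limits in this assay, and no step between them can be read. The compounds shown leave open how 3-(tert-butyl)phenyl in place of 4-aminophenyl changes the read-out.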